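The source may report more compounds than this note shows. Statements on the series, on what has been measured and on what is new or still open speak of the compounds shown alone.

Of the compounds shown here, two from this series have been tested in an assay on HEK293 cells for inhibition of Voltage-dependent T-type calcium channel subunit alpha-1I (Homo sapiens), read by FLIPR and calcium flux, with a stated time of 3 min; on this read-out higher numbers stand for weaker inhibition and lower numbers for stronger inhibition. Compound 1, `C[C@@H]1CN(Cc2ccccc2)c2cncc(F)c2[C@H](C)N1C(=O)Nc1cccnc1`, gives 133 nM. Compound 2, `COc1ccc(CNC(=O)N2[C@H](C)CN(CCC(C)C)c3cnccc3[C@@H]2C)cc1`, gives 25 nM. Of the two numbers, compound 2 has the lower one, and the gap between compound 1 and compound 2 is beyond the scatter of repeated measurements, so compound 2 is the stronger inhibitor of the pair.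

Compound 3, `COc1ccc(CNC(=O)N2[C@H](C)CN(Cc3ccc(C(F)(F)F)o3)c3cnccc3[C@@H]2C)cc1`, has not yet been tested. It differs from compound 2 in one place: 5-(trifluoromethyl)furan-2-yl in place of isobutyl on a saturated chain carbon bound to a nitrogen on an aromatic ring in a ring. Within the data shown here, no measured pair shows this particular exchange, so no step of known size can be leaned on. On balance, the expected step from compound 2 to compound 3 in this assay is a 1.6-fold higher number from compound 2 to compound 3 (0.20 log units; within the scatter), which is small and may not exceed the scatter. Compound 3 is therefore expected to give about 40 nM, with a plausible range from 10 nM to 160 nM.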

Compound 3, half-maximal inhibitory concentration: 11 nM
The estimate for compound 3 lay 3.6-fold (0.56 log units) above the measured number; low and high end bracket the measured number.
By their numbers in this assay, from the lowest: compound 3; then compound 2; then compound 1.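

Exchanging isobutyl for 5-(trifluoromethyl)furan-2-yl on this saturated chain carbon bound to a nitrogen on an aromatic ring gives a 2.3-fold lower number from compound 2 to compound 3 (0.36 log units; beyond the scatter) in this assay. This place therefore accepts an aromatic ring carrying a hydrogen-bond acceptor as well as a branched chain, and inhibition becomes stronger rather than weaker with the larger group. Nothing available explains which part of the new group accounts for this gain.

The compounds shown do not separate the furan ring from the trifluoromethyl group, and a plain furan-2-yl or a 5-methylfuran-2-yl in the same place would be needed to tell them apart. Also open, as far as these compounds go, is how a chain ending in an amine would read at this place in this assay.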